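The source may hold more compounds than are shown below. What is called first, only, known or untested is meant among the compounds shown, and "the series" means these compounds.

Measured so far in an ADME assay on GES1 cells (Homo sapiens) for inhibition, read by MTT assay, with a stated time of 72 h; on this read-out lower numbers stand for stronger inhibition and higher numbers for weaker inhibition:

Compound 1, `Cc1cc(Nc2cc(-c3ccccc3)[nH]n2)n2nc(SCc3c(Cl)cccc3Cl)nc2n1`, gives 39600 nM.
Compound 2, `Cc1cc(Nc2cc(-c3cccs3)[nH]n2)n2nc(SCc3ccc(Br)cc3)nc2n1`, gives 38700 nM.
Compound 3, `Cc1cc(Nc2ccn(Cc3ccccc3)n2)n2nc(SCc3ccc(Br)cc3)nc2n1`, gives 44400 nM.

All three numbers sit within the usual scatter of one another, so none of them can be told apart on this read-out. Compound 1 lies closest to compound 2 and furthest from compound 3, yet even that gap stays within the scatter.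

Compound 4, `Cc1cc(Nc2cc(-c3ccccc3)[nH]n2)n2nc(SCc3ccccc3Br)nc2n1`, is not yet measured. It differs from compound 1 by one change: 2-bromophenyl in place of 2,6-dichlorophenyl on a saturated chain carbon bound to a sulfur. For the measured compounds named here, no step between measured compounds matches this change. Since the three measured compounds, which vary widely in their benzyl groups, give practically the same number, the step of a 1.0-fold higher number from compound 1 to compound 4 (0.00 log units; within the scatter) is expected to stay within the scatter. Compound 4 is therefore estimated at 40000 nM, with a range from 20000 nM to 80000 nM.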

Compound 4, half-maximal inhibitory concentration: 41100 nM
Beside the measured number, compound 4's estimate is 1.0-fold (0.01 log units) below it; measured number inside the range.
By their numbers in this assay, from the lowest: compounds 2, 1, 4 and 3 (each within the scatter of the next).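

In this assay, the step of a 1.0-fold higher number from compound 1 to compound 4 (0.02 log units; within the scatter) comes from putting 2-bromophenyl in place of 2,6-dichlorophenyl on a saturated chain carbon bound to a sulfur. This is the first pair shown that differs in one place only, so the comparison of these two groups can be read directly, and the number stays within the scatter. Nothing measured here offers an explanation for this result.

On these data alone, whether a group of another kind at this place, such as an amine or a carboxylic acid, would give a number beyond the scatter stays open. So does the outcome of a longer chain between the sulfur and the ring.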